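The compounds below may be only part of what the source reports. "The series", "measured", "known", "first", "only" and "open" are said of these compounds alone.

Working notes on the series, read in a functional assay on MGC-803 cells (Homo sapiens) for inhibition, read by sulforhodamine B assay; on this read-out lower numbers stand for stronger inhibition and higher numbers for weaker inhibition. Going by the values given here, compound 1 (`O=C1C(Nc2ccc(I)cc2)=CC(=O)c2c1nc1n2[C@H]2OC[C@@H](O)[C@H]2OC1`) gives 2150 nM, and this is the only numeric value so far. Compound 2 (`O=C1C=C(N2CCC2)C(=O)c2c1nc1n2[C@H]2OC[C@@H](O)[C@H]2OC1`) reads > 16000 nM, which is a limit of the assay and not a number. Compound 1 is therefore the sole numeric reference point for what follows.

Compound 3 (`CCc1ccc(NC2=CC(=O)c3c(nc4n3[C@H]3OC[C@@H](O)[C@H]3OC4)C2=O)cc1`) keeps the core of compound 1 and changes one group: ethyl in place of iodo on an aromatic carbon. This is ethyl in place of iodo on an aromatic carbon, para to a large group.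

Among the compounds with values here, no measured pair shows this change, so the expectation in this assay has no direct precedent. A small shift towards weaker inhibition is expected, most likely not beyond the usual scatter. The estimated change is a 1.3-fold higher number from compound 1 to compound 3 (0.11 log units; within the scatter). For compound 3 the expected value is 2800 nM, with an estimated range of 1000 nM to 8000 nM.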

Compound 3, half-maximal inhibitory concentration: 1110 nM
Compound 3: middle estimate off by 2.5-fold (0.40 log units), on the high side; the measured number falls inside the stated range.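

In this assay the change from (4-iodophenyl)amino to (4-ethylphenyl)amino gives a 1.9-fold lower number from compound 1 to compound 3 (0.29 log units; within the scatter) and so leaves the two compounds indistinguishable on this read-out. The place para to a large group on this six-membered aromatic ring therefore carries either iodo or ethyl with no separable difference, even though one iodine gives way to two carbons. Nothing shown accounts for this result.

From the compounds shown here alone, whether an amine, a carboxylic acid or a longer chain such as butyl at this place would read within the same range stays open, as does the reading of the unsubstituted phenyl. Going by these compounds alone, compound 2 reads > 16000 nM as a limit of the assay and not a number, so it gives no size for a step at the amino group.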